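Series notes: carbamoyl in place of a fluorophenyl group

The compounds below may be only part of what the source reports. "The series", "measured", "known", "first", "only" and "open" are said of these compounds alone.

Measured so far:
compound 1, `Cc1n[nH]c(C(=O)O)c1Cc1cccc(-c2cccc(F)c2)c1`, 20%
compound 2, `Cc1n[nH]c(C(=O)O)c1Cc1ccc(-c2ccc(OC(F)(F)F)cc2)cc1`, 11%
compound 3, `Cc1n[nH]c(C(=O)O)c1Cc1ccccc1C(F)(F)F`, 13%

All three were tested in an assay on isolated protein for inhibition of 2-Hydroxyacid oxidase 2 (Homo sapiens), tested at 1 uM; a lower number here means a weaker effect, a higher number a stronger effect of the compound at the concentration tested. Compound 1 gives 20%, the highest of the three numbers, but its gap to compound 3 and its gap to compound 2 both fall within the usual scatter, so no order among the three can be read from these values. All three compounds carry the same core and differ only in the substituent on the benzyl ring; none of the pairs differs in a single place.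

Compound 4, `Cc1n[nH]c(C(=O)O)c1Cc1cccc(C(N)=O)c1`, has not been measured. It differs from compound 1 in one place: carbamoyl in place of 3-fluorophenyl on an aromatic carbon. Going by the values given here, no measured pair shows what a comparable change does in this assay, so the direction of the step from compound 1 is open. Given that compound 1 sits at 20% and the other two compounds sit in the same band, a step no larger than the scatter is expected, in either direction. The step expected from compound 1 to compound 4 in this assay is a number 8 percentage points lower from compound 1 to compound 4 (within the scatter). The value of compound 4 is estimated at 12%, with a range from 0% to 28%.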

Compound 4, a percentage reported as inhibition, at one concentration (the size of the read-out at that concentration, not a potency): 8%
Compound 4: middle estimate off by 4 percentage points, on the high side; the range from low to high includes it.
By their numbers in this assay, from the lowest: compounds 4, 2, 3 and 1 (each within the scatter of the next, the first and the last beyond it).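

Carbamoyl in place of 3-fluorophenyl on this aromatic carbon gives a number 12 percentage points lower from compound 1 to compound 4 (beyond the scatter) in this assay, the first single-place change that can be read in the series, and a modest one. It shows that the number responds to what this position carries, which the three earlier compounds could not show. The change removes a six-membered aromatic ring and brings in a hydrogen-bond donor and a hydrogen-bond acceptor, and no available data indicate which of these differences accounts for the lower number.

A plain phenyl, a nitrile or a carboxylic acid at the same carbon would help separate loss of the ring from gain of the amide, but the compounds shown do not include them. As far as these compounds go, whether carbamoyl has a similar effect on other carbons of that ring also remains open.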